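A few compounds are considered here, and "the series" means these few. Any claim that something is new, unique, unknown or untested is made for them only; others in the source may bear on it.

Compound 1, `COc1ccc(C2CC(c3ccccc3)=NN2C2=NC(=O)/C(=C3\C(=O)Nc4ccccc43)S2)cc1`, gives 1640 nM in a functional assay on cells (Leukemia cell, Homo sapiens) for cytotoxicity, read by sulforhodamine B assay, with a stated time of 48 h; on this read-out lower numbers stand for stronger inhibition of growth and higher numbers for weaker inhibition of growth.
Compound 2, `COc1ccc(C2CC(c3ccccc3)=NN2C2=NC(=O)/C(=C3\C(=O)Nc4ccc(Br)cc43)S2)cc1`, gives 250 nM in this assay.
Compound 3, `COc1ccc(C2=NN(C3=NC(=O)/C(=C4\C(=O)Nc5ccccc54)S3)C(c3ccc(OC)cc3)C2)cc1`, gives 100000 nM in this assay.

Compound 3 stands highest of the three numbers in this assay, so it is the weakest inhibitor of growth measured here; its nearest neighbour is compound 1, and the step from compound 1 to compound 3 was a 61-fold higher number from compound 1 to compound 3 (1.79 log units; beyond the scatter), a change that arose from a methoxy in place of hydrogen on an aromatic carbon.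

Compound 4, `COc1ccc(C2=NN(C3=NC(=O)/C(=C4\C(=O)Nc5ccc(Br)cc54)S3)C(c3ccc(OC)cc3)C2)cc1`, differs from compound 3 in one place: bromo in place of hydrogen on an aromatic carbon. The same change has been measured once before, on the core without the extra methoxy, where the step from compound 1 to compound 2 was a 6.6-fold lower number from compound 1 to compound 2 (0.82 log units; beyond the scatter). Among the compounds with values here, that single step is the only guide, and it points to a lower number, of modest size, when the bromo enters. Whether the effect carries over onto the much weaker compound 3 is not known from these three compounds.

Compound 4 is therefore expected to give a lower number than compound 3 in this assay, with the step estimated at a 5.0-fold lower number from compound 3 to compound 4 (0.70 log units; beyond the scatter). The estimate for compound 4 is 20000 nM, within a range of 5000 nM to 100000 nM.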

Compound 4, concentration for 50% growth inhibition: 280 nM
For compound 4 the middle estimate is 71-fold (1.85 log units) above the measured one; the measured number lies below the stated range.
By their numbers in this assay, from the lowest: compounds 2 and 4 (each within the scatter of the next); then compound 1; then compound 3.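

Bromo in place of hydrogen on an aromatic carbon gives a 360-fold lower number from compound 3 to compound 4 (2.55 log units; beyond the scatter), so the same change does not bring the same gain on every core: the same change on two cores in this assay, a 6.6-fold lower number (0.82 log units; beyond the scatter) from compound 1 to compound 2 and a 360-fold lower number (2.55 log units; beyond the scatter) from compound 3 to compound 4, 54-fold (1.74 log units) apart, beyond the scatter of two such steps

The methoxy change now looks different too, since with the bromo already in place it gives a 1.1-fold higher number from compound 2 to compound 4 (0.05 log units; within the scatter), and the large loss seen without the bromo does not appear: the same change on two cores in this assay, a 61-fold higher number (1.79 log units; beyond the scatter) from compound 1 to compound 3 and a 1.1-fold higher number (0.05 log units; within the scatter) from compound 2 to compound 4, 54-fold (1.74 log units) apart, beyond the scatter of two such steps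

Across these four compounds, the two changes therefore do not simply add up, and the effect of each depends on whether the other is present, so the result of one change on one core would be a poor guide to its result on the other.

These compounds do not show whether the strong response belongs to bromo itself, or whether a chloro group, a fluoro group or an amine on the same aromatic carbon would also restore the growth inhibition lost in compound 3. They also leave open whether a hydroxyl group or a longer chain in place of the added methoxy would lose its penalty in the same way once the bromo is present.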